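Swapping the side chain of compound 3

A few compounds are considered here, and "the series" means these few. Any claim that something is new, unique, unknown or untested is made for them only; others in the source may bear on it.

Measured in a functional assay on MDA-MB-231 cells (Homo sapiens) for cytotoxicity, read by MTT assay, with a stated time of 24 h; on this read-out higher numbers stand for weaker inhibition and lower numbers for stronger inhibition:
- compound 1 `COc1ccc2c(c1)cc(-c1cc(OC)c(OC)c(OC)c1)n2Cc1ccccc1` gives > 30000 nM as a limit
- compound 2 `COc1ccc(Cn2c(-c3cc(OC)c(OC)c(OC)c3)cc3cc(OC)ccc32)cc1` gives > 30000 nM as a limit
- compound 3 `CCOCC(=O)Oc1ccc(Cn2c(-c3cc(OC)c(OC)c(OC)c3)cc3cc(OC)ccc32)cc1` gives > 30000 nM as a limit

Compound 3 rests at the limit of > 30000 nM in this assay, at which 3 of the 3 values shown sit, and so has no exact number of its own. Compound 4 `COc1ccc2c(c1)cc(-c1cc(OC)c(OC)c(OC)c1)n2Cc1ccc(OC(C)CN(C)C)cc1` keeps the shared core and differs from compound 3 by 1-((dimethylamino)methyl)ethyl in place of (ethoxymethyl)carbonyl on an oxygen on an aromatic ring in one place. In words, 1-((dimethylamino)methyl)ethyl stands in place of (ethoxymethyl)carbonyl on an oxygen on an aromatic ring.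

Going by the values given here, three measured steps bear on this change: there is a step that the two limits leave unreadable from compound 1 to compound 2 and a step that the two limits leave unreadable from compound 1 to compound 3 and a step that the two limits leave unreadable from compound 2 to compound 3 as well. None of them has a size that can be read, so they offer no measured guide to the new group. All that can be said is that neither of the two groups tried so far moved a compound off the limit. With compound 3 at > 30000 nM as a limit, only a modest change is expected in this assay and its direction can only be stronger inhibition. The estimated change is an at least 2.0-fold lower number from compound 3 to compound 4 (0.30 log units; that floor lies within the scatter) and it remains uncertain. Compound 4 is estimated at 15000 nM within an expected range from 4000 nM to 40000 nM and could equally return only a limit.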

Compound 4, half-maximal inhibitory concentration: 10600 nM
Estimate against measurement, compound 4: 1.4-fold (0.15 log units) above; low and high end bracket the measured number.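

Of the compounds shown, compound 4 alone returns an exact number in this assay, so a change on this oxygen on an aromatic ring can bring a compound off the limit. Putting 1-((dimethylamino)methyl)ethyl in place of (ethoxymethyl)carbonyl gives an at least 2.8-fold lower number from compound 3 to compound 4 (0.45 log units; beyond the scatter), putting it in place of methyl gives an at least 2.8-fold lower number from compound 2 to compound 4 (0.45 log units; beyond the scatter), and adding 1-((dimethylamino)methyl)ethoxy where only hydrogen stood gives an at least 2.8-fold lower number from compound 1 to compound 4 (0.45 log units; beyond the scatter). The steps among compound 1, compound 2 and compound 3 cannot be read, and these new steps give only minimum sizes, because each of them starts from a limit: the limit of > 30000 nM in this assay, at which 3 of the 4 values shown sit.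

The compounds shown leave open whether the nitrogen of the new group matters or its carbon chain alone would do, a question that a plain butyl group on the same oxygen could help to settle. Also open, from the compounds shown here alone, is whether a longer chain carrying the amine, or a morpholine ring in place of the dimethylamino group, would lower the number further.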